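The compounds below may be only part of what the source reports. "The series", "measured", "known", "first", "only" and "open" are said of these compounds alone.

In a functional assay on PC-3 cells (Homo sapiens) for antiproliferative activity, read by MTT assay, with a stated time of 48 h (a lower number here means a stronger inhibitor, a higher number a weaker inhibitor), compound 1 (`C#CCCOC(=O)c1ccc(C(CC)(CC)c2ccc(OCCC(O)(CC)CC)c(C)c2)n1CC`) gives > 50000 nM, which is a limit of the assay. Compound 2 (`CCC(C)C(NC(=O)c1ccc(C(CC)(CC)c2ccc(OCCC(O)(CC)CC)c(C)c2)n1CC)C(=O)OC`) gives > 50000 nM, also a limit, so it stands where (the limit of > 50000 nM in this assay, at which 2 of the 2 values shown sit). Compound 3 (`CCOC(=O)C(CC(=O)OC)NC(=O)c1ccc(C(CC)(CC)c2ccc(OCCC(O)(CC)CC)c(C)c2)n1CC`) differs from compound 2 by a group of 11 heavy atoms (7 carbon, 4 oxygen; no ring) in place of a group of 9 heavy atoms (7 carbon, 2 oxygen; no ring), on an amide-type nitrogen. No size can be carried over to this change because a step that the two limits leave unreadable from compound 1 to compound 2 gives none, so no step beyond the scatter is expected in this assay. The expected step is a step that the limit leaves unreadable from compound 2 to compound 3. For compound 3 the estimated value is 60000 nM, with an expected range of 25000 nM to 150000 nM.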

Compound 3, half-maximal inhibitory concentration: 5840 nM
Estimate against measurement, compound 3: 10-fold (1.01 log units) above; measured number below the stated range.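

Before compound 3, the values shown were only limits of the assay, and no change could be read from them: the limit of > 50000 nM in this assay, at which 2 of the 3 values shown sit. In this assay, a change on the amide-type nitrogen now has a readable effect, with the group of 11 heavy atoms in place of the group of 9 giving an at least 8.5-fold lower number from compound 2 to compound 3 (0.93 log units; beyond the scatter). The change on the carbonyl carbon, with the group of 12 heavy atoms in place of the group of 5, gives an at least 8.5-fold lower number from compound 1 to compound 3 (0.93 log units; beyond the scatter).

As far as these compounds go, it remains open which part of the entering group goes with this step. Also open, from the compounds shown here alone, is whether a carboxylic acid in place of an ester, or a longer chain on the amide-type nitrogen, would lower the number further.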